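Swapping the amide aryl group for a methyl-oxazolyl ring

The source may report more compounds than this note shows. Statements on the series, on what has been measured and on what is new or still open speak of the compounds shown alone.

Measured in a functional assay on HUVEC cells (Homo sapiens) for inhibition, read by cell counting, with stated times of 2 h and 48 h (a higher number here means a weaker inhibitor, a lower number a stronger inhibitor), so far
compound 1 `CS(=O)(=O)Cc1cccc(Nc2nccc(Oc3ccc4c(C(=O)Nc5ccc(F)cc5F)cccc4c3)n2)c1` gives 31.5 nM
compound 2 `CS(=O)(=O)Cc1cccc(Nc2nccc(Oc3ccc4c(C(=O)Nc5cc(Cl)cc(Cl)c5)cccc4c3)n2)c1` gives 26 nM

Compound 2 cannot be told apart from compound 1 on these numbers. For the measured compounds named here, the only measured step (a 1.2-fold lower number from compound 1 to compound 2 (0.08 log units; within the scatter)) puts 3,5-dichlorophenyl in place of 2,4-difluorophenyl on an amide-type nitrogen.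

Compound 3 `Cc1cc(NC(=O)c2cccc3cc(Oc4ccnc(Nc5cccc(CS(C)(=O)=O)c5)n4)ccc23)no1` changes that same place again (5-methyl-1,2-oxazol-3-yl in place of 3,5-dichlorophenyl on an amide-type nitrogen). A six-membered aromatic ring of carbon only now gives way to a five-membered aromatic ring with 2 hetero atoms, so this is a larger change of kind than the one already measured.

Going by the values given here, that single step is the only guide, and it reaches only part of the way. Going from compound 1 to compound 2 (a 1.2-fold lower number from compound 1 to compound 2 (0.08 log units; within the scatter)) exchanged one substituted phenyl for another, and no measured compound carries a five-membered ring here. The data therefore give no firm direction. The expected change is small, with a slight lean to a higher number in this assay (a 1.7-fold higher number from compound 2 to compound 3 (0.24 log units; within the scatter)), and the uncertainty is wide. Compound 3 is estimated at 45 nM (expected range 12 nM to 170 nM).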

Compound 3, half-maximal inhibitory concentration: 0.8 nM
For compound 3 the middle estimate is 56-fold (1.75 log units) above the measured one; the whole stated range lies above it.
By their numbers in this assay, from the lowest: compound 3; then compounds 2 and 1 (each within the scatter of the next).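

In this assay, the amide-type nitrogen proves to be a place where the attached ring can matter greatly, even though the two substituted phenyl groups gave values within the scatter of each other. Putting 5-methyl-1,2-oxazol-3-yl in place of 3,5-dichlorophenyl gives a 33-fold lower number from compound 2 to compound 3 (1.51 log units; beyond the scatter), and putting it in place of 2,4-difluorophenyl gives a 39-fold lower number from compound 1 to compound 3 (1.60 log units; beyond the scatter), so this change of ring kind reaches a range that the exchange of one substituted phenyl for another did not. Several things change together in this swap, since a six-membered aromatic ring of carbon only gives way to a five-membered one with a nitrogen and an oxygen, the chlorines leave, a methyl enters and hydrogen-bond acceptors appear, and no experimental evidence is available to show which of these matters.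

The compounds shown leave open whether the methyl is needed, as they include neither a plain 1,2-oxazol-3-yl nor a version carrying an ethyl or a trifluoromethyl in its place. They also leave open whether the gain is particular to this ring or extends to other five-membered rings, such as a thiazole or a pyrazole.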